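The source may hold more compounds than are shown below. What is called first, only, known or untested is meant among the compounds shown, and "the series" means these compounds.

Compound 3 `CCCSc1nc(N/N=C/c2ccc(N(C)C)cc2)c2nnn(Cc3ccccc3)c2n1`: 12200 nM
Compound 1 `CCCSc1nc(N/N=C(\C)c2ccc(OC)cc2)c2nnn(Cc3ccccc3)c2n1`: > 64000 nM
Compound 2 `CCCSc1nc(N/N=C/c2cc(OC)c(OC)c(OC)c2)c2nnn(Cc3ccccc3)c2n1`: > 64000 nM

Among the compounds with values here, in a functional assay on MCF7 cells (Homo sapiens) for antiproliferative activity, read by MTT assay, with a stated time of 72 h (a higher number here means a weaker inhibitor, a lower number a stronger inhibitor), compound 3 gives 12200 nM, the only true number among the three. For compound 1 the result is a limit of the assay, > 64000 nM. For compound 2 the result is likewise a limit, > 64000 nM. Compound 4 `CCCSc1nc(N/N=C/c2ccc3ccccc3c2)c2nnn(Cc3ccccc3)c2n1` is built from compound 3 by one exchange: naphthalen-2-yl in place of 4-(dimethylamino)phenyl on a carbon with a double bond to nitrogen. Within the data shown here, no step between two measured compounds is available to guide the size of this change, so only a rough expectation is possible. Given that compound 3 sits at 12200 nM and that (the limit of > 64000 nM in this assay, at which 2 of the 3 values shown sit), the step from compound 3 to compound 4 is expected to be a 2.5-fold higher number from compound 3 to compound 4 (0.39 log units; beyond the scatter), a modest loss in this assay. Compound 4 is therefore estimated at 30000 nM, within a range from 8000 nM to 100000 nM.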

Compound 4, half-maximal inhibitory concentration: > 64000 nM
Compound 4: a limit, no number (the forecaster's own chance of this, stated with the estimate: 45%); middle value at least 2.1-fold (0.32 log units) from the limit.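

On the carbon with a double bond to nitrogen, naphthalen-2-yl in place of 4-(dimethylamino)phenyl gives an at least 5.2-fold higher number from compound 3 to compound 4 (0.71 log units; beyond the scatter) in this assay. This is the only step shown between two compounds that differ in one place, and it shows that this exchange weakens activity beyond the scatter. The result for compound 4 is a limit, so the full size of the step stays unknown: the limit of > 64000 nM in this assay, at which 3 of the 4 values shown sit.

The compounds shown leave open whether the loss goes with the dimethylamino group leaving or with the second ring entering. From the compounds shown here alone, how a plain phenyl group or a diethylamino group would fare in this place also remains open.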